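A few compounds are considered here, and "the series" means these few. Any claim that something is new, unique, unknown or untested is made for them only; others in the source may bear on it.

Working notes on the series. Compound 3 `CCCCNC(=O)Nc1nc2ccc(NC(=O)c3c(Cl)cccc3Cl)cc2s1` stands second highest of three numbers in a functional assay on WI-38 VA13 cells (Homo sapiens) for cytotoxicity (a higher number here means that more compound is needed for the effect, a lower number that less compound is needed), where compound 3 gives 0.028 ug/mL. Its nearest neighbour is compound 2 `CCNC(=O)Nc1nc2ccc(NC(=O)c3c(Cl)cccc3Cl)cc2s1`, which gives 0.032 ug/mL; the step of a 1.1-fold lower number from compound 2 to compound 3 (0.06 log units; within the scatter) amounts to a lengthening of the alkyl chain on the urea nitrogen with no change beyond the scatter. The furthest is compound 1 `CC(C)COC(=O)Nc1nc2ccc(NC(=O)c3c(Cl)cccc3Cl)cc2s1`, which gives 0.0035 ug/mL; here the carbamate is exchanged for a urea, and the steps of an 8.0-fold higher number from compound 1 to compound 3 (0.90 log units; beyond the scatter) and a 9.1-fold higher number from compound 1 to compound 2 (0.96 log units; beyond the scatter) are both beyond the scatter and of similar size.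

Compound 4 `O=C(NCc1ccccc1)Nc1nc2ccc(NC(=O)c3c(Cl)cccc3Cl)cc2s1` carries the change (phenyl in place of propyl on a saturated chain carbon bound to an amide-type nitrogen). Of the measured steps, only a 1.1-fold lower number from compound 2 to compound 3 (0.06 log units; within the scatter) concerns the same part of the molecule, the chain on the urea nitrogen, and it lies within the scatter. The carbamate-to-urea steps from compound 1 do not bear on a change that keeps the urea intact. Within the data shown here, no measured step introduces an aromatic ring at this position, so the effect of the phenyl is not anchored by the data. The step of no change at the digits printed from compound 3 to compound 4 (within the scatter) is therefore expected to be small, with no direction favoured beyond the scatter. For compound 4 the estimate in this assay is 0.028 ug/mL, with a range from 0.008 ug/mL to 0.1 ug/mL.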

Compound 4, half-maximal effective concentration: 0.15 ug/mL
Beside the measured number, compound 4's estimate is 5.4-fold (0.73 log units) below it; measured number above the stated range.
By their numbers in this assay, from the lowest: compound 1; then compounds 3 and 2 (each within the scatter of the next); then compound 4.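

The chain on the urea nitrogen showed no change beyond the scatter between ethyl and butyl, but this position does respond to a benzyl group: in this assay the steps of a 5.4-fold higher number from compound 3 to compound 4 (0.73 log units; beyond the scatter) and a 4.7-fold higher number from compound 2 to compound 4 (0.67 log units; beyond the scatter) both run towards more compound being needed for the effect. Compared with the carbamate, the exchange of isobutoxy for benzylamino on the carbonyl carbon gives the largest step in the series, a 43-fold higher number from compound 1 to compound 4 (1.63 log units; beyond the scatter), so the urea with this group sits furthest from compound 1. Nothing available accounts for the difference between the alkyl chains and the benzyl group at this position.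

On these data alone, whether the step follows the aromatic ring itself or simply the larger group remains open, and a cyclohexylmethyl group, with a saturated six-membered ring in place of the phenyl, would separate the two. Also open, as far as these compounds go, is whether a longer link such as phenethyl, or an amine or carboxylic acid on the phenyl ring, would move the number further from that of compound 3 or back towards it.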